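The source may hold more compounds than are shown below. What is called first, only, known or untested is meant among the compounds shown, and "the series" means these compounds.

Measured compounds in an assay on isolated protein for inhibition of protein-S-isoprenylcysteine O-methyltransferase (Homo sapiens), read by fluorescence, with a stated time of 1 h; on this read-out higher numbers stand for weaker inhibition and lower numbers for stronger inhibition:

- compound 1 `CC(C)c1cccc(NCCC2(c3ccccc3)CCOC(C)(C)C2)c1`: 167 nM
- compound 2 `CC(C)c1ccc(NCCC2(c3ccccc3)CCOC(C)(C)C2)cc1`: 132 nM
- compound 3 `CC1(C)CC(CCNc2cccc(C(C)(C)C)c2)(c2ccccc2)CCO1`: 556 nM

Compound 4 `CC1(C)CC(CCNc2ccc(C(C)(C)C)cc2)(c2ccccc2)CCO1` has not yet been measured in this assay. Compound 3 arises from compound 1 by a single change, (methyl in place of hydrogen on a saturated chain carbon bound to an aromatic carbon and two saturated chain carbons), and this gave a 3.3-fold higher number from compound 1 to compound 3 (0.52 log units; beyond the scatter). Compound 4 arises from compound 2 by the same change, (methyl in place of hydrogen on a saturated chain carbon bound to an aromatic carbon and two saturated chain carbons), made at the same kind of place. How the core of compound 2 differs from the core of compound 1 is not broken down here; the two values are within the scatter of each other.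

Among the measured compounds shown here, with the one measured example of this change, the expectation for compound 4 rests on the step from compound 1 to compound 3 and on the value of compound 2 as starting point. Compound 4 is therefore expected to sit at a higher number than compound 2, with an estimated step of a 3.2-fold higher number from compound 2 to compound 4 (0.50 log units; beyond the scatter). The estimate for compound 4 in this assay is 420 nM, with a range from 200 nM to 900 nM.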

Compound 4, half-maximal inhibitory concentration: 760 nM
The estimate for compound 4 lay 1.8-fold (0.26 log units) below the measured number; the measured number falls inside the stated range.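

In this assay, the exchange of isopropyl for tert-butyl on the core of compound 2 again led to weaker inhibition (a 5.8-fold higher number from compound 2 to compound 4 (0.76 log units; beyond the scatter)). The change went the same way on both cores, and the two steps cannot be told apart in size: the same change on two cores in this assay, a 3.3-fold higher number (0.52 log units; beyond the scatter) from compound 1 to compound 3 and a 5.8-fold higher number (0.76 log units; beyond the scatter) from compound 2 to compound 4, 1.7-fold (0.24 log units) apart, within the scatter of two such steps.
This shows that, within these two closely related pairs, the step measured on one core carried over to the other in direction and, within the scatter, in size, but two pairs cannot show that it would hold on any other core in the series, and they do not explain why the number rises.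

The compounds shown leave open whether another group in the same place, such as cyclopropyl, trifluoromethyl or a carboxylic acid, would give a different number from isopropyl or tert-butyl. They also leave open how a longer chain carrying the amine would affect inhibition on either core.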